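Nitro Addition on a Cytotoxicity Series

The source may hold more compounds than are shown below. What is called first, only, known or untested is meant among the compounds shown, and "the series" means these compounds.

Measured compounds:
Compound 1, `CCS(=O)(=O)Nc1ccc(NC(=O)c2ccc(Cl)cc2)cc1OC` — 60100 nM
Compound 2, `CCS(=O)(=O)Nc1ccc(NC(=O)c2ccc(Cl)c([N+](=O)[O-])c2)cc1OC` — 5660 nM
Compound 3, `CS(=O)(=O)Nc1ccc(NC(=O)c2ccc(Cl)cc2)cc1F` — 22300 nM

In an ADME assay on RAW264.7 cells (Mus musculus) for cytotoxicity, read by MTT assay, with a stated time of 48 h (on this read-out lower numbers stand for stronger inhibition and higher numbers for weaker inhibition), compound 1 gives 60100 nM, and compound 2 gives 5660 nM. The change between them is nitro in place of hydrogen on an aromatic carbon, and it produced an 11-fold lower number from compound 1 to compound 2 (1.03 log units; beyond the scatter). Compound 3 gives 22300 nM in this assay; its number is beyond the scatter from both compound 1 and compound 2, lying between them. The difference between the core of compound 3 and the core of compound 1 is not broken down here.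

Compound 4, `CS(=O)(=O)Nc1ccc(NC(=O)c2ccc(Cl)c([N+](=O)[O-])c2)cc1F`, has not yet been measured in this assay. It differs from compound 3 by nitro in place of hydrogen on an aromatic carbon, which is the same change that was made from compound 1 to compound 2. Because compound 1 to compound 2 gave an 11-fold lower number from compound 1 to compound 2 (1.03 log units; beyond the scatter), a step of roughly similar size is expected from compound 3 to compound 4 in this assay, that is an 8.9-fold lower number from compound 3 to compound 4 (0.95 log units; beyond the scatter). This expectation rests on a single observed instance of the change, so the range is kept wide. For compound 4 the estimated value in this assay is 2500 nM, expected to fall between 900 nM and 7000 nM.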

Compound 4, half-maximal inhibitory concentration: 102000 nM
For compound 4 the middle estimate is 41-fold (1.61 log units) below the measured one; measured number outside the range, above it.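

In this assay, nitro in place of hydrogen on an aromatic carbon gave a 4.6-fold higher number from compound 3 to compound 4 (0.66 log units; beyond the scatter), the opposite direction to the step seen on the core of compound 1. Set side by side, the two results show that the effect of this change did not carry from one core to the other in this series, in either size or direction: the same change on two cores in this assay, an 11-fold lower number (1.03 log units; beyond the scatter) from compound 1 to compound 2 and a 4.6-fold higher number (0.66 log units; beyond the scatter) from compound 3 to compound 4, 49-fold (1.69 log units) apart, beyond the scatter of two such steps

This does not show which feature of the cores goes with the reversal, as the two cores differ in more than one place, and two pairs cannot show how the change would behave on any further core.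

The compounds shown leave open how an amine or a carboxylic acid at the same place on the ring would behave on either core. They also leave open what the nitro change would do on a core that combines the ethyl chain with fluoro, or the methyl chain with methoxy.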